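This account rests on a few compounds, and the source may have more. Where it says the series, first, only, none or still open, it means among the compounds named here.

Results in an ADME assay on J774.A1 cells (Mus musculus) for cytotoxicity, read by MTT assay, with a stated time of 48 h; a higher number here means that more compound is tolerated, a lower number that less compound is tolerated:

Compound 1 (`COC(=O)c1c([N+](=O)[O-])noc1-c1ccccc1`): "not determined" (no result reported)
Compound 2 (`COC(=O)c1c([N+](=O)[O-])noc1-c1cccc([N+](=O)[O-])c1`): "not determined" (no result reported)
Compound 3 (`COC(=O)c1c([N+](=O)[O-])noc1-c1ccc(Cl)cc1Cl`): 19700 nM

These three compounds share a core and differ in the groups on the outer six-membered ring. The next compound to be tested is compound 4 (`COC(=O)c1c([N+](=O)[O-])noc1-c1cccc(-c2ncoc2C)c1`). Its starting point offers no number to compare against: in this assay compound 2 has the entry "not determined" (no result reported) and therefore no place on the scale. Compound 1 has the same gap.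

The structural change is 5-methyl-1,3-oxazol-4-yl in place of nitro on an aromatic carbon; in words, 5-methyl-1,3-oxazol-4-yl stands in place of nitro on an aromatic carbon. Among the measured compounds shown here, no pair of measured compounds shows what a change of this kind does, so the data cannot size this step directly.

For the measured compounds named here, the only available number is that of compound 3 at 19700 nM, and the expectation is anchored there. In this assay no shift beyond the usual scatter of repeated measurements is expected from that anchor, and neither direction is favoured. With a single number as support, the range must stay wide. For compound 4 the estimated half-maximal cytotoxic concentration is 20000 nM, with an expected range from 6000 nM to 70000 nM.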

Compound 4, half-maximal cytotoxic concentration: 18500 nM
Compound 4: middle estimate off by 1.1-fold (0.03 log units), on the high side; the range from low to high includes it.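

No step can be read for compound 4, since compound 2, which differs from it in one place, offers no number for comparison, and compound 3 differs from it in more than one place. From the compounds shown here alone, what 5-methyl-1,3-oxazol-4-yl in place of nitro does to tolerated concentration stays open. No evidence here explains the value of compound 4.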